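Working notes: from compound 2 to compound 3

A few compounds are considered here, and "the series" means these few. Any claim that something is new, unique, unknown or untested is made for them only; others in the source may bear on it.

Values in a functional assay on K562 cells (Homo sapiens) for cytotoxicity, read by trypan blue exclusion, with a stated time of 96 h; a lower number here means a stronger inhibitor, a higher number a weaker inhibitor:
- compound 1 `COc1cc(OC)c(/C=C/S(=O)(=O)Nc2ccc(F)c([N+](=O)[O-])c2)c(OC)c1` gives 75000 nM
- compound 2 `COC(=O)C(C)(C)Nc1cc(NS(=O)(=O)/C=C/c2c(OC)cc(OC)cc2OC)ccc1OC` gives 300 nM

Compound 2 holds the lower of the two values in this assay, and the gap to compound 1 lies beyond the scatter. The two compounds differ in more than one place, so the gap cannot be assigned to any single change.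

The next compound is compound 3 `COc1cc(OC)c(/C=C/S(=O)(=O)Nc2ccc(OC)c(NC(C(=O)O)c3ccccc3)c2)c(OC)c1`, not yet measured. It carries carboxy(phenyl)methyl in place of 1-(methoxycarbonyl)-1-methylethyl on a nitrogen on an aromatic ring. Going by the values given here, neither measured compound carries the entering group, and no measured pair isolates this kind of change, so the expectation is weakly supported. A moderate rise in the number, meaning a weaker inhibitor, is expected from the level of compound 2 at 300 nM as a starting point. The expected size is a 3.3-fold higher number from compound 2 to compound 3 (0.52 log units; beyond the scatter) on this estimate. The estimate for compound 3 is 1000 nM as a middle value, with an expected range of 120 nM to 9000 nM in this wide first guess.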

Compound 3, half-maximal inhibitory concentration: 300 nM
The estimate for compound 3 lay 3.3-fold (0.52 log units) above the measured number; the measured number falls inside the stated range.
By their numbers in this assay, from the lowest: compounds 2 and 3 (each within the scatter of the next); then compound 1.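

In this assay, replacing 1-(methoxycarbonyl)-1-methylethyl with carboxy(phenyl)methyl on a nitrogen on an aromatic ring gives no change at the digits printed from compound 2 to compound 3 (within the scatter). Going by these compounds alone, this is the first step that differs in one place, and it shows that this nitrogen can carry either group without a change in the read-out beyond the scatter, although the entering group brings a six-membered aromatic ring of carbon only and a hydrogen-bond donor that the leaving group lacks. The result does not show whether these features have no effect or whether their effects cancel, and no measurement at hand accounts for it.

The compounds shown leave open how the parts of the entering group contribute: a plain benzyl group on the same nitrogen, or a methyl ester in place of the carboxylic acid of carboxy(phenyl)methyl, would separate the aromatic ring from the acid. Also open, from the compounds shown here alone, is whether this nitrogen needs a carbon substituent at all, which an unsubstituted amine, compared with compound 3 at 300 nM, would test.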